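Furan-2-yl for 2-cyanophenyl: what the cell tolerates

This account rests on a few compounds, and the source may have more. Where it says the series, first, only, none or still open, it means among the compounds named here.

Three compounds have so far been measured in an ADME assay on HepG2 cells (Homo sapiens) for cytotoxicity, read by MTT assay, with a stated time of 72 h; a higher number here means that more compound is tolerated, a lower number that less compound is tolerated:

Compound 1 `N/C(=N/O)c1ccc(C2=C(S(=O)(=O)c3ccc(F)cc3)CC(c3ccccc3)(c3ccccc3)O2)cc1` gives 19200 nM.
Compound 2 `CC1(c2ccc(-c3ccc(/C(N)=N\O)cc3)cc2)CC(S(=O)(=O)c2ccc(F)cc2)=C(c2ccc(/C(N)=N\O)cc2)O1` gives 15300 nM.
Compound 3 `CC1(c2ccc(-c3ccccc3C#N)cc2)CC(S(=O)(=O)c2ccc(F)cc2)=C(c2ccc(/C(N)=N\O)cc2)O1` gives 58300 nM.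

Compound 3 stands highest of the three numbers. Its nearest neighbour is compound 1, whose value lies beyond the scatter below it, and furthest is compound 2, also beyond the scatter. Going by the values given here, the one single-point step among the measured compounds is a 3.8-fold higher number from compound 2 to compound 3 (0.58 log units; beyond the scatter), a modest rise.

Compound 4 `CC1(c2ccc(-c3ccco3)cc2)CC(S(=O)(=O)c2ccc(F)cc2)=C(c2ccc(/C(N)=N\O)cc2)O1` takes the next step from compound 3: furan-2-yl in place of 2-cyanophenyl on an aromatic carbon. Among the compounds with values here, the only measured step that bears on it is the one from compound 2 to compound 3, which touched the same position of the shared core and was modest in size; it exchanged different groups, however, so it gives no direct guide to the size or direction of the present change. With so little to lean on, the expectation for compound 4 in this assay is a step within the scatter, a 1.5-fold lower number from compound 3 to compound 4 (0.16 log units; within the scatter), with wide uncertainty either way. Compound 4 is therefore estimated at 40000 nM, in a range from 15000 nM to 100000 nM.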

Compound 4, half-maximal cytotoxic concentration: 7010 nM
Beside the measured number, compound 4's estimate is 5.7-fold (0.76 log units) above it; measured number outside the range, below it.
By their numbers in this assay, from the lowest: compound 4; then compounds 2 and 1 (each within the scatter of the next); then compound 3.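

Furan-2-yl takes this position lower than either group measured there before, an 8.3-fold lower number from compound 3 to compound 4 (0.92 log units; beyond the scatter) and a 2.2-fold lower number from compound 2 to compound 4 (0.34 log units; beyond the scatter), so compound 4 now stands lowest of the compounds in this assay. The earlier step showed only a rise at this aromatic carbon; the new steps show that the number can move in either direction here, with compound 3 at the top and compound 4 at the bottom of this short series, while compound 2, with its six-membered aromatic ring, lies between them, beyond the scatter of both. Nothing measured here explains why the change from 2-cyanophenyl to furan-2-yl lowers the number.

The compounds shown leave open whether the lower number goes with the five-membered ring itself or with the loss of the nitrile, as an unsubstituted phenyl, a thiophen-2-yl or a furan-3-yl at this position would separate those two readings. They also leave open whether the same order of groups would hold on the core of compound 1, which carries none of them.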